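Carboxycyclopropylphenyl in place of methoxy on the carbamate core

A few compounds are considered here, and "the series" means these few. Any claim that something is new, unique, unknown or untested is made for them only; others in the source may bear on it.

Measured so far:
compound 1 `COc1ccc(-c2cnn(C)c2NC(=O)O[C@H](C)c2ccccc2)cc1` — > 30000 nM
compound 2 `C[C@@H](OC(=O)Nc1c(-c2ccccc2F)cnn1C)c1ccccc1Cl` — > 30000 nM

Both values are limits of an in vitro functional assay on chem-1 cells for antagonist activity at lysophosphatidic acid receptor 3 (Homo sapiens), read by FLIPR and calcium flux, with stated times of 30 min and 100 s (a lower number here means a stronger inhibitor, a higher number a weaker inhibitor), rather than numbers. In this assay compound 1 gives > 30000 nM, which is a limit. Compound 2 gives > 30000 nM, likewise a limit. Compound 1 therefore stands at the limit of > 30000 nM in this assay, at which 2 of the 2 values shown sit, and nothing in the measured pair sets an order between them.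

The unmeasured compound 3 `C[C@@H](OC(=O)Nc1c(-c2ccc(-c3ccc(C4(C(=O)O)CC4)cc3)cc2)cnn1C)c1ccccc1` differs from compound 1 by 4-(1-carboxycyclopropyl)phenyl in place of methoxy on an aromatic carbon. For the measured compounds named here, no step between measured compounds exists here to calibrate a change of this kind, so the size of the step rests on the structural change alone. The step from compound 1 to compound 3 is expected to be an at least 10-fold lower number from compound 1 to compound 3 (1.00 log units; beyond the scatter), toward stronger inhibition. Compound 3 is estimated at 3000 nM, with a range from 300 nM to 30000 nM.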

Compound 3, half-maximal inhibitory concentration: 8340 nM
Beside the measured number, compound 3's estimate is 2.8-fold (0.44 log units) below it, within the range that was stated.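

Putting 4-(1-carboxycyclopropyl)phenyl in place of methoxy on this aromatic carbon gives an at least 3.5-fold lower number from compound 1 to compound 3 (0.55 log units; beyond the scatter) in this assay, toward stronger inhibition. This position, para to a large group, can therefore take a far larger substituent without the compound staying out of range, and compound 3 is the only compound shown that reads as a number, while the other two remain at a limit: the limit of > 30000 nM in this assay, at which 2 of the 3 values shown sit. Since the starting value is a limit, the step gives only a lower bound on the size of the change.

The compounds shown leave open how much of the step comes from the added phenyl ring, the cyclopropane or the carboxylic acid. They also leave open whether a tetrazole or a primary amide could stand in for that carboxylic acid.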